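The compounds below may be only part of what the source reports. "The series", "measured", "known", "first", "only" and "open" are said of these compounds alone.

Compound 1 `CCCOC(=O)c1c(C)coc1-c1ccc2c(CC)cccc2c1OC`: > 10 ug/mL, a limit
Compound 2 `CCc1cccc2c(OC)c(-c3occ(C)c3CO)ccc12`: 7.2 ug/mL

Both compounds were tested in a functional assay on DU-145 cells (Homo sapiens) for cytotoxicity, read by MTT assay, with a stated time of 72 h; a lower number here means that less compound is needed, a higher number that more compound is needed for the effect. Within the data shown here, compound 2 gives 7.2 ug/mL, the only true number so far. Compound 1 gives > 10 ug/mL, which is a limit of the assay and not a number.

The next compound is compound 3 `CCc1cccc2c(OC)c(-c3occ(C)c3CBr)ccc12`, which changes the hydroxymethyl group of compound 2 to bromomethyl: bromo in place of hydroxy on a saturated chain carbon bound to an aromatic carbon. Among the measured compounds shown here, only one measured step touches this group: an at least 1.3-fold lower number from compound 1 to compound 2 (0.14 log units; that floor lies within the scatter), where hydroxymethyl replaced propoxycarbonyl. That step has only a floor, and the floor lies within the scatter, so it gives no firm size for a new change. For the measured compounds named here, no compound carrying bromo has been measured yet. The expected step is therefore a 1.2-fold lower number from compound 2 to compound 3 (0.08 log units; within the scatter), with no shift beyond the scatter in either direction. For compound 3 the estimated value is 6 ug/mL, with an expected range from 2 ug/mL to 14 ug/mL.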

Compound 3, concentration for half-maximal effect: > 10 ug/mL
Compound 3: a limit, no number; the forecaster's own chance of this, stated with the estimate: 15%; at least 1.6-fold (0.22 log units) between middle value and limit.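

Putting bromo in place of hydroxy on this saturated chain carbon removes the hydrogen-bond donor and acceptor of the hydroxy group, and in this assay it gives an at least 1.3-fold higher number from compound 2 to compound 3 (0.14 log units; that floor lies within the scatter). On these data alone, nothing here shows bromomethyl needing less compound than hydroxymethyl, but the true size of the step stays unknown, since the value of compound 3 is a limit of the assay and not a number. The step from compound 1 to compound 3 cannot be read, and one limit now governs most of this small set: the limit of > 10 ug/mL in this assay, at which 2 of the 3 values shown sit.

As far as these compounds go, how far compound 3 lies past its limit remains open, so the change could be small or large. Also open, from the compounds shown here alone, is how an amine or a methoxy group would behave in place of the hydroxy on this carbon.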